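This account rests on a few compounds, and the source may have more. Where it says the series, first, only, none or still open, it means among the compounds named here.

Values so far in a functional assay on U-937 cells (Homo sapiens) for cytotoxicity, read by MTT assay, with a stated time of 3 days (a lower number here means a stronger inhibitor, a higher number a weaker inhibitor), are as follows.

- Compound 1 `N#Cc1c(NN)nc(SCc2nc3ccccc3[nH]2)nc1-c1ccccc1` gives 3.9 nM 
- Compound 2 `N#Cc1c(Nc2ccccc2)nc(SCc2nc3ccccc3[nH]2)nc1-c1ccccc1` gives 3.28 nM 
- Compound 3 `CNc1nc(SCc2nc3ccccc3[nH]2)nc(-c2ccccc2)c1C#N` gives 19.2 nM 

Compound 3 carries the highest number of the three, which makes it the weakest inhibitor so far. Its gaps to the other two both lie beyond the scatter, as a 4.9-fold higher number from compound 1 to compound 3 (0.69 log units; beyond the scatter) and a 5.9-fold higher number from compound 2 to compound 3 (0.77 log units; beyond the scatter) show.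

The next compound is compound 4 `N#Cc1c(Nc2ccccn2)nc(SCc2nc3ccccc3[nH]2)nc1-c1ccccc1`, which has pyridin-2-yl in place of methyl on a nitrogen on an aromatic ring.

The closest guide is a 5.9-fold higher number from compound 2 to compound 3 (0.77 log units; beyond the scatter) in which methyl replaced phenyl and the number rose. Read backwards, that step suggests a modest fall when a six-membered aromatic ring returns to this nitrogen. The step of a 1.2-fold lower number from compound 1 to compound 2 (0.08 log units; within the scatter) stays within the scatter, so those two groups cannot be told apart in this assay here. Within the data shown here, no measured compound carries pyridin-2-yl, so what its ring nitrogen adds remains unknown, and the range must stay wide.

A modest fall is therefore expected, estimated as a 3.8-fold lower number from compound 3 to compound 4 (0.58 log units; beyond the scatter) in size. For compound 4 the estimated value is 5 nM within an expected range of 2 nM to 14 nM in this assay.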

Compound 4, half-maximal inhibitory concentration: 2.55 nM
For compound 4 the middle estimate is 2.0-fold (0.29 log units) above the measured one; low and high end bracket the measured number.
By their numbers in this assay, from the lowest: compounds 4, 2 and 1 (each within the scatter of the next); then compound 3.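

In this assay, the step of a 7.5-fold lower number from compound 3 to compound 4 (0.88 log units; beyond the scatter) confirms that methyl stands apart at this nitrogen, now against a second aromatic ring as well as phenyl. The ring nitrogen of pyridin-2-yl makes no difference that can be read, since a 1.3-fold lower number from compound 2 to compound 4 (0.11 log units; within the scatter) stays within the scatter, and so does a 1.5-fold lower number from compound 1 to compound 4 (0.18 log units; within the scatter), which also shows that a ring is not needed here for a low number, as the amino group of compound 1 has none. Nothing available explains why methyl alone gives the higher number.

Still open, as far as these compounds go, is whether that higher number belongs to methyl alone or extends to ethyl or a longer chain on this nitrogen, and how a group ending in a carboxylic acid or an amine would behave there. All four compounds share the rest of their structure and are compared only in this assay, so these readings hold for this nitrogen on this core in this one assay.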